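Adding a third methoxy group to the weaker bromophenyl sulfone

This account rests on a few compounds, and the source may have more. Where it says the series, first, only, none or still open, it means among the compounds named here.

Compound 1 `COc1cc(Nc2nc3ccccc3nc2S(=O)(=O)c2ccc(C)cc2)cc(OC)c1OC`: 4850 nM
Compound 2 `COc1cc(Nc2nc3ccccc3nc2S(=O)(=O)c2ccc(Br)cc2)cc(OC)c1`: 18200 nM

In a functional assay on PC-3 cells (Homo sapiens) for cytotoxicity, read by MTT assay, with a stated time of 72 h (on this read-out higher numbers stand for weaker inhibition and lower numbers for stronger inhibition), compound 2 gives the highest of the two numbers, and compound 1 sits at a lower number in this assay, a gap beyond the usual scatter. Compound 3 `COc1cc(Nc2nc3ccccc3nc2S(=O)(=O)c2ccc(Br)cc2)cc(OC)c1OC` is not yet measured; it differs from compound 2 by methoxy in place of hydrogen on an aromatic carbon. Compound 1 already carries three methoxy groups and a lower number, so compound 3 is expected to move downward in this assay, with a step from compound 2 to compound 3 of about a 2.6-fold lower number from compound 2 to compound 3 (0.41 log units; beyond the scatter). Compound 3 is estimated at 7000 nM, with a range from 2500 nM to 20000 nM.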

Compound 3, half-maximal inhibitory concentration: 19800 nM
The estimate for compound 3 lay 2.8-fold (0.45 log units) below the measured number, within the range that was stated.
By their numbers in this assay, from the lowest: compound 1; then compounds 2 and 3 (each within the scatter of the next).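

With the bromo group kept, methoxy in place of hydrogen on this aromatic carbon, ortho to two methoxy groups, leaves this assay unchanged (a 1.1-fold higher number from compound 2 to compound 3 (0.04 log units; within the scatter)), so the third methoxy group does not account for the lower number of compound 1. With the three methoxy groups held constant, bromo in place of methyl separates the pair (a 4.1-fold higher number from compound 1 to compound 3 (0.61 log units; beyond the scatter)), a modest step. Nothing measured here explains either step. The compounds shown leave open whether a hydroxyl or an ethoxy group on this carbon would shift the number, and whether methoxy there matters when methyl replaces bromo.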